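This account rests on a few compounds, and the source may have more. Where it says the series, first, only, none or still open, it means among the compounds named here.

Working notes on the urea series.

Among the compounds with values here, in a functional assay on HepG2 cells (Homo sapiens) for inhibition, with a stated time of 72 h (a lower number here means a stronger inhibitor, a higher number a weaker inhibitor), compound 2 `O=C(Nc1ccccc1)Nc1nc(Sc2c[nH]c3ccccc23)cc(N2CCN(Cc3ccccc3)CC2)n1` gives 8160 nM, the lowest of the three numbers measured so far. Compound 1 `Cc1cc(Cl)ccc1NC(=O)Nc1nc(Sc2c[nH]c3ccccc23)cc(N2CCN(Cc3ccccc3)CC2)n1` gives 11700 nM, and compound 3 `COc1ccc(NC(=O)Nc2nc(Nc3cc(OC)cc(OC)c3)cc(Sc3c[nH]c4ccccc34)n2)cc1` gives 17400 nM. Only the gap from compound 2 to compound 3 lies beyond the scatter; the gap to compound 1 does not, so compound 2 cannot be called the strongest inhibitor of the set on this evidence.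

Compound 4 `Cc1ccc(C)c(NC(=O)Nc2nc(Sc3c[nH]c4ccccc34)cc(N3CCN(Cc4ccccc4)CC3)n2)c1` is the next to be measured. Against compound 2 the change is 2,5-dimethylphenyl in place of phenyl on an amide-type nitrogen. Within the data shown here, one measured step bears on the same position: a 1.4-fold lower number from compound 1 to compound 2 (0.16 log units; within the scatter), where a substituted phenyl gave way to plain phenyl with no movement beyond the scatter. Among the measured compounds shown here, compound 4 reverses the direction by placing two methyl groups on that ring, and the single comparison available indicates that substitution on this phenyl does not move this assay in a meaningful way. No step beyond the scatter is therefore expected, with a slight lean towards a higher number in line with compound 1.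

The estimated step this implies is a 1.2-fold higher number from compound 2 to compound 4 (0.07 log units; within the scatter), expected to stay within the scatter. Compound 4 is expected to give 9500 nM, with a range of 4500 nM to 20000 nM.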

Compound 4, half-maximal inhibitory concentration: 16400 nM
The estimate for compound 4 lay 1.7-fold (0.24 log units) below the measured number, and the stated range covers the measured number.
By their numbers in this assay, from the lowest: compounds 2, 1, 4 and 3 (each within the scatter of the next, the first and the last beyond it).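

With 2,5-dimethylphenyl in place of phenyl on the amide-type nitrogen, this assay gives a 2.0-fold higher number from compound 2 to compound 4 (0.30 log units; within the scatter), so a second substituted phenyl now stands against plain phenyl, and this step also stays within the scatter. The two substituted groups compare as a 1.4-fold higher number from compound 1 to compound 4 (0.15 log units; within the scatter), which means that 2,5-dimethylphenyl and 4-chloro-2-methylphenyl cannot be told apart here, and that across these two groups and phenyl, this position has so far shown no step beyond the scatter. No supporting data accompany these numbers, so nothing can be said about what lies behind them.

As far as these compounds go, the groups on this nitrogen are all phenyl rings, carrying nothing other than methyl or chloro, so it remains open whether an amine or a carboxylic acid on that ring, or a longer alkyl chain in place of the ring, would produce a step beyond the scatter. Compound 3 differs from the other three compounds in more than one place, so no single change can be read from it.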